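A few compounds are considered here, and "the series" means these few. Any claim that something is new, unique, unknown or untested is made for them only; others in the source may bear on it.

Compound 1 `CCc1nc(-c2ccc(COc3cccc(C(=O)NO)c3)cc2)no1` gives 34700 nM in an assay on isolated protein for inhibition of sphingomyelin phosphodiesterase (Homo sapiens), read by fluorescence, with a stated time of 30 min; on this read-out higher numbers stand for weaker inhibition and lower numbers for stronger inhibition.
Compound 2 `O=C(NO)c1cccc(OCc2ccc(-c3noc(-c4ccccc4)n3)cc2)c1` gives only a limit of this assay, > 100000 nM.

Compound 2 thus sits at the weak end of the two numbers shown, at the limit of > 100000 nM in this assay, at which 1 of the 2 values shown sits; its true inhibition is not pinned to a number. Going by the values given here, the one measured step shows that the growth from ethyl to phenyl cost potency: an at least 2.8-fold higher number from compound 1 to compound 2 (0.45 log units; beyond the scatter).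

Compound 3 `O=C(NO)c1cccc(OCc2ccc(-c3noc(-c4ccc(Br)cc4)n3)cc2)c1` differs from compound 2 in one place: bromo in place of hydrogen on an aromatic carbon. Among the compounds with values here, no measured step involves a bromo group, so no direct guide exists for this change. Within the data shown here, the only measured step on this part of the core, from compound 1 to compound 2, ran toward weaker inhibition, and it already put compound 2 at the limit of this assay. Adding a bromo group is a further enlargement of the same end of the molecule, so no recovery of inhibition is expected; the expected step is a step that the limit leaves unreadable from compound 2 to compound 3, that is, none beyond the scatter. Compound 3 is therefore estimated at 120000 nM, within 40000 nM to 400000 nM, and most likely reported again only as a limit.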

Compound 3, half-maximal inhibitory concentration: > 100000 nM
Compound 3: no number, only a limit; the forecaster's own chance of this, stated with the estimate: 70%; the middle value does not contradict the limit.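

In this assay, the 4-bromophenyl group at this end of the molecule gives the same direction of change as the plain phenyl group, toward weaker inhibition than with ethyl: an at least 2.8-fold higher number from compound 1 to compound 3 (0.45 log units; beyond the scatter). The effect of the bromo group itself cannot be read, since compound 2 and compound 3 are both recorded only as limits, and the result adds a second compound to that same limit: the limit of > 100000 nM in this assay, at which 2 of the 3 values shown sit. What is new is narrow: putting a bromo group on the phenyl ring of compound 2 does not bring inhibition back into the range that gives a number, and compound 1 remains the only compound shown with a true measured value.

Whether ethyl is close to the best group at this end remains open, as the compounds shown do not reveal what a methyl group, a propyl chain or a cyclopropyl ring would give in its place. From the compounds shown here alone, it is also open how an amine, a carboxylic acid or a fluorine atom at the place of the bromo group would read, or whether any such group would lift compound 2 clear of its limit.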